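A chloro for methyl swap on the anilide ring

A few compounds are considered here, and "the series" means these few. Any claim that something is new, unique, unknown or untested is made for them only; others in the source may bear on it.

Compound 3 `CC1=C(C(=O)Nc2ccc(C)cc2)C(c2cn(-c3ccccc3)nc2-c2ccc(Cl)cc2)NC(=O)N1` is one of three measured members of a small series built on a shared core. In a functional assay on MCF7 cells (Homo sapiens) for inhibition, read by sulforhodamine B assay, with a stated time of 24 h (on this read-out lower numbers stand for stronger inhibition of growth and higher numbers for weaker inhibition of growth), compound 3 gives 69700 nM. Its nearest neighbour is compound 2 `CC1=C(C(=O)Nc2ccc(C)cc2)C(c2cn(-c3ccccc3)nc2-c2ccccc2)NC(=O)N1`, which gives 71700 nM; the step from one to the other, a 1.0-fold lower number from compound 2 to compound 3 (0.01 log units; within the scatter), lies within the scatter. Compound 1 `CCOC(=O)C1=C(C)NC(=O)NC1c1cn(-c2ccccc2)nc1-c1ccccc1` gives 60800 nM, and the step of a 1.2-fold higher number from compound 1 to compound 2 (0.07 log units; within the scatter) also stays within the scatter, so the three values cannot be separated from one another.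

Compound 4 `CC1=C(C(=O)Nc2ccc(Cl)cc2)C(c2cn(-c3ccccc3)nc2-c2ccc(Cl)cc2)NC(=O)N1` differs from compound 3 by chloro in place of methyl on an aromatic carbon. Among the measured compounds shown here, no measured step changes a methyl into a chloro on this ring; the step from compound 2 to compound 3 exchanged hydrogen for chloro on the other aromatic ring and stayed within the scatter, and the step from compound 1 to compound 2 replaced the whole ethoxy with a (4-methylphenyl)amino and also stayed within the scatter. No step beyond the scatter is therefore expected, and the estimated step is a 1.1-fold lower number from compound 3 to compound 4 (0.02 log units; within the scatter). Compound 4 is estimated at 66000 nM, with a range from 30000 nM to 145000 nM.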

Compound 4, concentration for 50% growth inhibition: 56900 nM
Compound 4: middle estimate off by 1.2-fold (0.06 log units), on the high side; the measured number falls inside the stated range.
By their numbers in this assay, from the lowest: compounds 4, 1, 3 and 2 (each within the scatter of the next).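

Replacing the (4-methylphenyl)carbamoyl of compound 3 with the (4-chlorophenyl)carbamoyl of compound 4 is the only step shown that alters the group para to a large group on this ring, and in this assay it gives a 1.2-fold lower number from compound 3 to compound 4 (0.09 log units; within the scatter). Exchanging methyl for chloro here therefore does not separate the two compounds, and each of the three steps shown, all made in different places, now lies within the scatter. No measurement shown bears on what lies behind this result.

On these data alone, whether an amine or a carboxylic acid in place of the methyl of compound 3 would give a step beyond the scatter remains open. Also open, as far as these compounds go, is what a longer chain in place of the ethoxy of compound 1 would do in this assay.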